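The compounds below may be only part of what the source reports. "The series", "measured", "known", "first", "only" and "open" are said of these compounds alone.

In a physicochemical assay for solubility, in phosphate buffer, with a stated time of 18 h, at pH 7.4 (on this read-out higher numbers stand for higher solubility and lower numbers for lower solubility), compound 3 (`CCN(CC)C(=O)COc1cc2c(-n3nc(-c4ccccn4)nc3N)ncnc2cc1OC`) gives 42000 nM, the highest of the three numbers, while compound 1 (`COc1cc2ncnc(-n3nc(-c4ccccn4)nc3N)c2cc1[N+](=O)[O-]`) gives 2000 nM and compound 2 (`COc1cc2ncnc(-n3nc(-c4ccccn4)nc3N)c2cc1N`) gives 3000 nM. Compound 4 (`CCCCCCOC(=O)NCCCOc1cc2c(-n3nc(-c4ccccn4)nc3N)ncnc2cc1OC`) carries 2-((hexyloxycarbonyl)amino)ethyl in place of diethylcarbamoyl on a saturated chain carbon bound to an oxygen on an aromatic ring. Among the measured compounds shown here, no measured step makes this exact change. For the measured compounds named here, the nearest guides are a 21-fold higher number from compound 1 to compound 3 (1.32 log units; beyond the scatter) and a 14-fold higher number from compound 2 to compound 3 (1.15 log units; beyond the scatter), both large, and they show only that a change in this substituent can move the number widely. Judged from these steps, a large move to a lower number is expected, estimated as an 11-fold lower number from compound 3 to compound 4 (1.02 log units; beyond the scatter) in this assay. For compound 4 the estimate is 4000 nM, with an expected range of 800 nM to 20000 nM.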

Compound 4, solubility: 1000 nM
Estimate against measurement, compound 4: 4.0-fold (0.60 log units) above; measured number inside the range.
By their numbers in this assay, from the lowest: compounds 4, 1 and 2 (each within the scatter of the next, the first and the last beyond it); then compound 3.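

In this assay the replacement of diethylcarbamoyl by 2-((hexyloxycarbonyl)amino)ethyl gives a 42-fold lower number from compound 3 to compound 4 (1.62 log units; beyond the scatter) on the saturated chain carbon, so the high number of compound 3 does not carry over to this other chain. The earlier steps shown here changed the group on the aromatic carbon, whereas this one keeps the oxygen on the aromatic ring and shows that the group beyond it can alone move the number widely. Nothing available bears on the cause of this drop. The compounds shown leave open whether a shorter alkyl carbamate, a dimethylamine or a carboxylic acid on this chain would stay near compound 3 or near compound 4.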